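The compounds below may be only part of what the source reports. "The series", "measured", "known", "first", "only" and "open" are said of these compounds alone.

For the measured compounds named here, compound 1 `Nc1cc(N)c2nc(-c3ccccc3)c(Oc3ccc(Cl)c(Cl)c3)nc2c1` holds the lower of the two numbers measured so far in a functional assay on OVCAR-5 cells (Homo sapiens) for inhibition, read by sulforhodamine B assay, with a stated time of 48 h (on this read-out higher numbers stand for weaker inhibition of growth and lower numbers for stronger inhibition of growth), where compound 1 gives 25100 nM. Compound 2 `CCOC(=O)[C@H](CCC(=O)O)NC(=O)c1ccc(Oc2nc3cc(N)cc(N)c3nc2-c2ccccc2)cc1` gives 79400 nM, a weaker result. Compound 3 `Nc1cc(N)c2nc(-c3ccccc3)c(Sc3ccc(Cl)c(Cl)c3)nc2c1` keeps the core of compound 1 but carries (3,4-dichlorophenyl)sulfanyl in place of 3,4-dichlorophenoxy on an aromatic carbon. Going by the values given here, no pair of measured compounds shows an exchange of this kind, so the size of the step is uncertain; a change of this sort is expected to stay near the scatter, with no clear direction. Compound 3 is therefore expected to give about 20000 nM, within 6000 nM to 60000 nM. That estimate means a step of a 1.3-fold lower number from compound 1 to compound 3 (0.10 log units; within the scatter).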

Compound 3, concentration for 50% growth inhibition: 38900 nM
Estimate against measurement, compound 3: 1.9-fold (0.29 log units) below; low and high end bracket the measured number.
By their numbers in this assay, from the lowest: compounds 1 and 3 (each within the scatter of the next); then compound 2.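

The step of a 1.5-fold higher number from compound 1 to compound 3 (0.19 log units; within the scatter) in this assay comes from putting (3,4-dichlorophenyl)sulfanyl in place of 3,4-dichlorophenoxy on the aromatic carbon next to the ring nitrogen. At this position, then, a sulfur link and an oxygen link cannot be told apart on this read-out, although both compounds give high numbers. Nothing available explains this match.

Still open, going by these compounds, is whether an amine or a methylene link at this position would give a similar number. Also open, on these data alone, is how the number would respond if the chlorine atoms on the ring were replaced by methoxy groups.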